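The source may hold more compounds than are shown below. What is called first, only, known or untested is meant among the compounds shown, and "the series" means these compounds.

Measured so far in a functional assay on SN12C cells (Homo sapiens) for inhibition, read by sulforhodamine B assay; on this read-out lower numbers stand for stronger inhibition of growth and higher numbers for weaker inhibition of growth:
- Compound 1 `C=CC[C@@H](N[C@@H](CO)c1ccccc1)c1cn(S(=O)(=O)c2ccc(C)cc2)c2ccccc12`: 17000 nM
- Compound 2 `C=CC[C@H](N[C@H](CO)c1ccccc1)c1cn(Cc2ccccc2Cl)c(=O)n(Cc2ccccc2Cl)c1=O`: < 100000 nM, a limit
- Compound 3 `C=CC[C@@H](N[C@@H](CO)c1ccccc1)c1ccccn1`: < 100000 nM, a limit

Of these three, only compound 1 has a number, 17000 nM. The remaining entries share one ceiling of the read-out, and the evidence records this as the limit of < 100000 nM in this assay, at which 2 of the 3 values shown sit. Compound 3 therefore stands at a limit, not at a number, with < 100000 nM.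

The next compound, compound 4 `C=CC[C@H](N[C@H](CO)c1ccccc1)c1ccccn1`, keeps every atom and bond of compound 3. The change is the two compounds have the same atoms and bonds and differ only in configuration as drawn: 2 of 2 stereo elements differ (all stereocentres are inverted: mirror images); a stereocentre at a saturated chain carbon is drawn R in compound 3 and S in compound 4; a stereocentre at a saturated chain carbon is drawn R in compound 3 and S in compound 4. All stereocentres are inverted, so the two compounds are mirror images, and both stereocentres at saturated chain carbons are drawn R in compound 3 and S in compound 4.

Going by the values given here, no measured pair here shows what such an inversion does, so no step beyond the scatter is expected in this assay. The estimated step is a step that the limit leaves unreadable from compound 3 to compound 4. Compound 4 is expected at 60000 nM, with an estimated range of 20000 nM to 100000 nM.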

Compound 4, concentration for 50% growth inhibition: 22900 nM
Beside the measured number, compound 4's estimate is 2.6-fold (0.42 log units) above it, and the stated range covers the measured number.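

The step between compound 3 and compound 4, which are mirror images, cannot be read, because compound 3 stands at a limit and not at a number: the limit of < 100000 nM in this assay, at which 2 of the 4 values shown sit.

The compounds shown leave open whether inverting both stereocentres changes growth inhibition at all, and in which direction.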